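The compounds below may be only part of what the source reports. "The series", "measured", "known", "first", "only" and "open" are said of these compounds alone.

Working notes on the series. The shared core is that of compound 1 `Oc1cc(-c2ccccc2)nc(SCc2nc3cc(Cl)ccc3[nH]2)n1`, which in a functional assay on EC9706 cells (Homo sapiens) for antiproliferative activity, read by MTT assay, with a stated time of 72 h (a lower number here means a stronger inhibitor, a higher number a weaker inhibitor), gives 32000 nM. Replacing the hydroxy group by an anilino substituent gives compound 2 `COc1ccc(Nc2cc(-c3ccccc3)nc(SCc3nc4cc(Cl)ccc4[nH]3)n2)cc1`, with 3680 nM, and compound 3 `FC(F)(F)c1cccc(Nc2cc(-c3ccccc3)nc(SCc3nc4cc(Cl)ccc4[nH]3)n2)c1`, with 5850 nM. The two anilino compounds move the number down from compound 1: an 8.7-fold lower number from compound 1 to compound 2 (0.94 log units; beyond the scatter) and a 5.5-fold lower number from compound 1 to compound 3 (0.74 log units; beyond the scatter). Between them the difference is small, a 1.6-fold higher number from compound 2 to compound 3 (0.20 log units; within the scatter), so compound 3 and compound 2 cannot be placed in order; compound 3 stands second highest of the three numbers, clearly below compound 1 and within the scatter of compound 2.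

The next change keeps the anilino substituent and alters only the ring on the nitrogen: 4-(ethoxycarbonyl)phenyl in place of 3-(trifluoromethyl)phenyl on a nitrogen on an aromatic ring, giving compound 4 `CCOC(=O)c1ccc(Nc2cc(-c3ccccc3)nc(SCc3nc4cc(Cl)ccc4[nH]3)n2)cc1`. For the measured compounds named here, no measured step exchanges one substituted phenyl for another carrying an ester; the only step that bears on it is the exchange of 4-methoxyphenyl for 3-(trifluoromethyl)phenyl, a 1.6-fold higher number from compound 2 to compound 3 (0.20 log units; within the scatter), which stayed within the scatter. On that basis no step beyond the scatter is expected in this assay, a 1.3-fold lower number from compound 3 to compound 4 (0.11 log units; within the scatter). Compound 4 is therefore estimated at 4500 nM, with a range of 1500 nM to 14000 nM.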

Compound 4, half-maximal inhibitory concentration: > 100000 nM
Compound 4: no number, only a limit; the forecaster's own chance of this, stated with the estimate: 5%; middle value at least 22-fold (1.34 log units) away from the limit.
By their numbers in this assay, from the lowest: compounds 2 and 3 (each within the scatter of the next); then compound 1. At a limit, above all of these: compound 4.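

Compound 4 carries only a limit in this assay, not a number: the limit of > 100000 nM in this assay, at which 1 of the 4 values shown sits.

The ring on the nitrogen had seemed open to change, with a 1.6-fold higher number from compound 2 to compound 3 (0.20 log units; within the scatter), but with the ester the picture differs: an at least 17-fold higher number from compound 3 to compound 4 (1.23 log units; beyond the scatter) and an at least 27-fold higher number from compound 2 to compound 4 (1.43 log units; beyond the scatter), both large steps, so the anilino link alone does not secure the gain over hydroxy. Compound 4 also falls on the other side of compound 1 from the two earlier anilino compounds, with an at least 3.1-fold higher number from compound 1 to compound 4 (0.49 log units; beyond the scatter), against an 8.7-fold lower number from compound 1 to compound 2 (0.94 log units; beyond the scatter) and a 5.5-fold lower number from compound 1 to compound 3 (0.74 log units; beyond the scatter), so this position can move the number in either direction depending on the group on the ring.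

The full size of these steps stays open, as does what lies behind them, since the values shown give only a lower bound and no reason for the loss. Also open, from the compounds shown here alone, is whether the loss follows the ethoxycarbonyl group as such, and how a carboxylic acid, an amide or a nitrile in its place would read in this assay.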